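The source may report more compounds than this note shows. Statements on the series, on what has been measured and on what is new or still open speak of the compounds shown alone.

The three measured compounds share one core and differ only in where a chloro group sits or in the drawn configuration. In an ADME assay on the whole organism with Oryza sativa as the target, tested at 1 uM (a higher number here means a weaker effect of the compound at the concentration tested, a lower number a stronger effect), compound 1 `C[C@@H](NC(=O)Nc1ccccc1Cl)c1ccccc1` gives 103%, compound 2 `C[C@@H](NC(=O)Nc1cccc(Cl)c1)c1ccccc1` gives 91%, and compound 3 `C[C@H](NC(=O)Nc1cccc(Cl)c1)c1ccccc1` gives 99%. Compound 2 and compound 3 cannot be told apart, since a number 8 percentage points higher from compound 2 to compound 3 (within the scatter) and they differ only through (the fact that compounds 2 and 3 differ only in the configuration as drawn); compound 1 stands beyond the scatter above compound 2. Compound 4 `C[C@@H](NC(=O)Nc1cc(Cl)ccc1Cl)c1ccccc1` arises from compound 2 by chloro in place of hydrogen on an aromatic carbon. Within the data shown here, no measured step adds a chloro group, so none bears directly on this change; compound 1 also carries a single chloro group and gives the higher number. Compound 4 is therefore expected to give 98%, with a range from 85% to 110%. That estimate means a step of a number 7 percentage points higher from compound 2 to compound 4 (within the scatter), expected to stay within the scatter.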

Compound 4, a percentage reported as activity, at one concentration (the size of the read-out at that concentration, not a potency): 100%
Beside the measured number, compound 4's estimate is 2 percentage points below it; the measured number falls inside the stated range.
By their numbers in this assay, from the lowest: compounds 2, 3, 4 and 1 (each within the scatter of the next, the first and the last beyond it).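

Compound 4 carries a further chloro group compared with both compound 1 and compound 2, and in this assay it cannot be told apart from either, with a number 9 percentage points higher from compound 2 to compound 4 (within the scatter) and a number 3 percentage points lower from compound 1 to compound 4 (within the scatter). Reached from either side, this change gives no step beyond the scatter. Nothing available explains this result.

Still open, from the compounds shown here alone, is whether an amine or a methoxy group in place of hydrogen on this aromatic carbon would give a step beyond the scatter. Also open, going by these compounds, is whether the drawn configuration matters in compound 4.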